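The source may hold more compounds than are shown below. What is called first, only, known or untested is meant among the compounds shown, and "the series" means these compounds.

Of the compounds shown here, three have so far been measured in an assay on isolated protein for inhibition of high affinity 3',5'-cyclic-AMP phosphodiesterase 7A (Homo sapiens), read by cAMP accumulation, with a stated time of 10 min (on this read-out higher numbers stand for weaker inhibition and lower numbers for stronger inhibition), and every one of them returned a limit of the assay rather than a number.

Compound 1 `COc1nc2c(c(=O)n(C)c(=O)n2C)n1CC(=O)NCc1ccccc1Cl` gives > 200000 nM, a limit.
Compound 2 `CCOc1nc2c(c(=O)n(C)c(=O)n2C)n1CC(=O)Nc1cccc(Cl)c1` gives > 200000 nM, a limit.
Compound 3 `CCOc1nc2c(c(=O)n(C)c(=O)n2C)n1CC(=O)Nc1ccc(C(C)(C)C)cc1` gives > 200000 nM, a limit.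

Compound 3 therefore stands only at a limit in this assay, and the two further values shown are limits as well; all three sit at the limit of > 200000 nM in this assay, at which 3 of the 3 values shown sit. Among the compounds with values here, the one step between measured compounds that differ in a single place, a step that the two limits leave unreadable from compound 2 to compound 3, is left unreadable by the two limits, so it says nothing about the size or direction of a change on the amide-type nitrogen.

Compound 4 `CCOc1nc2c(c(=O)n(C)c(=O)n2C)n1CC(=O)NCc1ccccc1Cl` differs from compound 3 in one place: 2-chlorobenzyl in place of 4-(tert-butyl)phenyl on an amide-type nitrogen. Compound 1 carries the same 2-chlorobenzyl group on its amide-type nitrogen, and compound 1 likewise reached only the limit. Within the data shown here, no measured step bears on this change in a readable way, so no step beyond the scatter can be predicted in either direction for this assay. On that basis the expectation is that compound 4 will again sit at or around the limit, with a step that the limit leaves unreadable from compound 3 to compound 4 expected to be unreadable, and its estimated value in this assay is 300000 nM with a range from 150000 nM to 1000000 nM.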

Compound 4, half-maximal inhibitory concentration: > 200000 nM
Compound 4 was reported as a limit; the forecaster's own chance of this, stated with the estimate: 85%; the middle value lies beyond the limit too.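

In this assay compound 4 gives > 200000 nM, a limit. The steps joining compound 4 to compound 1, compound 2 and compound 3 therefore cannot be read, with every value at the same limit: the limit of > 200000 nM in this assay, at which 4 of the 4 values shown sit.

The compounds shown leave open whether any group on the amide-type nitrogen would give a measurable value in this assay.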